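Ring amine in place of the chain amine at the fluoro-bearing carbon

The compounds below may be only part of what the source reports. "The series", "measured", "known", "first", "only" and "open" are said of these compounds alone.

Compound 2 `CNCCCCNc1cc2c(cc1F)c(=O)c(C(=O)O)cn2Cc1ccc(-c2ccccc2)cc1` gives 88300 nM in an assay on isolated protein for inhibition of DNA topoisomerase 1 (Homo sapiens), with a stated time of 15 min (a higher number here means a weaker inhibitor, a lower number a stronger inhibitor), the lowest of the two numbers here, with compound 1 `NC[C@@H]1CCN(c2cc3c(cc2F)c(=O)c(C(=O)O)cn3Cc2ccc(-n3cccn3)cc2)C1` alongside at 91600 nM, within the scatter of it. Compound 3 `CNCCCCNc1c(F)cc2c(=O)c(C(=O)O)cn(Cc3ccc(-c4ccccc4)cc3)c2c1OC` reaches only the limit > 200000 nM in this assay. Going by the values given here, the one measured step, an at least 2.2-fold higher number from compound 2 to compound 3 (0.35 log units; beyond the scatter), sits at the limit of > 200000 nM in this assay, at which 1 of the 3 values shown sits, and does not touch the amine side chain. Compound 4 `N[C@@H]1CCN(c2cc3c(cc2F)c(=O)c(C(=O)O)cn3Cc2ccc(-c3ccccc3)cc2)C1` carries 3-aminopyrrolidin-1-yl in place of (4-(methylamino)butyl)amino on an aromatic carbon. Among the compounds with values here, no measured step bears on this change; the nearest hint is compound 1, whose value lies within the scatter of compound 2 despite its different ring amine. The step is therefore expected to be a 1.0-fold higher number from compound 2 to compound 4 (0.01 log units; within the scatter), none beyond the scatter. Compound 4 is estimated at 90000 nM, between 40000 nM and 200000 nM.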

Compound 4, half-maximal inhibitory concentration: 63600 nM
Estimate against measurement, compound 4: 1.4-fold (0.15 log units) above, and the stated range covers the measured number.
By their numbers in this assay, from the lowest: compounds 4, 2 and 1 (each within the scatter of the next). At a limit, above all of these: compound 3.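

In this assay, replacing the chain amine with the ring amine on this aromatic carbon, ortho to a fluoro group, gives a 1.4-fold lower number from compound 2 to compound 4 (0.14 log units; within the scatter). Going by these compounds alone, this is the first direct reading at the amine position, and it shows that the (4-(methylamino)butyl)amino chain and the 3-aminopyrrolidin-1-yl ring cannot be told apart here. Nothing shown offers a reason for this step.

Still open, going by these compounds, is whether a piperazine or a longer amine chain at this position would move the number beyond the scatter. On these data alone, the effect of replacing the carboxylic acid with an amide is also open.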